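Methyl for Trifluoromethoxy: Cytotoxicity Limit Expected to Hold

This account rests on a few compounds, and the source may have more. Where it says the series, first, only, none or still open, it means among the compounds named here.

compound 1 `O=C1Nc2ccc(F)cc2/C1=N/NC(=S)Nc1ccccc1` in an ADME assay on RD cells (Homo sapiens) for cytotoxicity; on this read-out lower numbers stand for higher toxicity in this test and higher numbers for lower toxicity in this test: > 25000 nM
compound 2 `O=C1Nc2ccc(OC(F)(F)F)cc2/C1=N/NC(=S)Nc1ccccc1` in this assay: > 25000 nM

In this assay compound 2 gives > 25000 nM, which is a limit of the assay and not a number. Compound 1 likewise gives > 25000 nM, also a limit. The change to compound 3 `Cc1ccc2c(c1)/C(=N/NC(=S)Nc1ccccc1)C(=O)N2` is methyl in place of trifluoromethoxy on an aromatic carbon. Among the compounds with values here, the only measured step touching this position, a step that the two limits leave unreadable from compound 1 to compound 2, cannot be read, since (the limit of > 25000 nM in this assay, at which 2 of the 2 values shown sit). Compound 3 is therefore expected to show no step beyond the scatter, a step that the limit leaves unreadable from compound 2 to compound 3. The estimate for compound 3 is 30000 nM, within 15000 nM to 100000 nM, most likely reported again as a limit.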

Compound 3, half-maximal cytotoxic concentration: > 25000 nM
Compound 3 was reported as a limit; the forecaster's own chance of this, stated with the estimate: 85%; the middle value does not contradict the limit.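

Compound 3 also gives only a limit of the assay and not a number, so no step can be read among compound 1, compound 2 and compound 3: the limit of > 25000 nM in this assay, at which 3 of the 3 values shown sit. The compounds shown leave open whether the fluoro, trifluoromethoxy and methyl compounds differ at all in cytotoxicity.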